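This account rests on a few compounds, and the source may have more. Where it says the series, first, only, none or still open, it means among the compounds named here.

Measured compounds:
- compound 1, `O=C(O)CCCC/C=C(/CCCc1ccccc1)c1cccnc1`: 65 nM
- compound 2, `O=C(O)C(CCC/C=C(\c1ccccc1)c1cccnc1)C1(O)CCCC1`: 65 nM
- compound 3, `O=C(O)CCCCCC(c1ccccc1)c1cccnc1`: 2700 nM

All three were tested in an assay (Equus caballus) for inhibition of Thromboxane-A synthase (Homo sapiens), using microsomes; a higher number here means a weaker inhibitor, a lower number a stronger inhibitor. Compound 2 and compound 1 stand level at the digits shown, and together they give the lowest numbers of the three. Compound 3 gives a much higher number in this assay, a gap that lies well beyond the scatter of repeated measurements, so compound 3 is the weakest inhibitor of the three.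

Compound 4, `CC(C)CSC(CCC/C=C(\c1ccccc1)c1cccnc1)C(=O)O`, has not yet been measured. It differs from compound 2 in one place:

isobutylsulfanyl in place of 1-hydroxycyclopentyl on a saturated chain carbon bound to a carbonyl carbon and a saturated chain carbon

Among the measured compounds shown here, no pair of measured compounds shows the effect of such a change, so the expectation rests on compound 2 alone. The change is expected to leave the number close to that of compound 2, with at most a modest shift toward a weaker inhibitor a 1.5-fold higher number from compound 2 to compound 4 (0.19 log units; within the scatter). Compound 4 is therefore estimated at 100 nM, with a likely range from 30 nM to 400 nM.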

Compound 4, half-maximal inhibitory concentration: 110 nM
Compound 4: the middle estimate sits 1.1-fold (0.04 log units) below what was measured; low and high end bracket the measured number.
By their numbers in this assay, from the lowest: compounds 1, 2 and 4 (each within the scatter of the next); then compound 3.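

Putting isobutylsulfanyl in place of 1-hydroxycyclopentyl, on a saturated chain carbon bound to a carbonyl carbon and a saturated chain carbon, gives a 1.7-fold higher number from compound 2 to compound 4 (0.23 log units; within the scatter) in this assay, so the two compounds cannot be told apart. For this pair, the ring and the hydrogen-bond donor of 1-hydroxycyclopentyl are therefore not needed to keep the number at this level, and a group with no ring, no donor and a sulfur atom serves equally well. Nothing measured here gives a reason for this match.

The compounds shown leave open how a plain hydrogen, an amine or a longer alkylsulfanyl chain would read at this place, so the limits of what it accepts are unknown. They also leave open whether the sulfur matters, which isobutoxy, with oxygen in its place, could test.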